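The source may report more compounds than this note shows. Statements on the series, on what has been measured and on what is new or still open speak of the compounds shown alone.

Three compounds of the series carry a number in an assay on L1.2 cells for binding affinity to C-C chemokine receptor type 8 (Homo sapiens); a higher number here means a weaker inhibitor, a lower number a stronger inhibitor. Compound 1 `O=C(Nc1ccc(S(=O)(=O)N2CCOCC2)c2ccccc12)c1ccccc1` gives 7750 nM in this assay. Compound 2 `CCOC(=O)N1CCC(NS(=O)(=O)c2ccc(NCCCc3ccccc3)c3ccccc23)CC1` gives 32.1 nM. Compound 3 `Cc1ccccc1C(=O)Nc1ccc(S(=O)(=O)NC2CCN(C(=O)CCN)CC2)c2ccccc12` gives 11.3 nM, the lowest of the three numbers: compound 2 sits nearest, beyond the scatter, and compound 1 furthest. Compound 4 `Cc1ccccc1C(=O)Nc1ccc(S(=O)(=O)NC2CCN(C(=O)N3CCOCC3)CC2)c2ccccc12` has no number yet. It differs from compound 3 in one place: morpholin-4-yl in place of 2-aminoethyl on a carbonyl carbon. For the measured compounds named here, no measured pair shows this change, so its size is open. The shared core and the amide-type nitrogen in a ring are kept. A modest rise in the number, expected as a 2.2-fold higher number from compound 3 to compound 4 (0.34 log units; beyond the scatter), seems most likely, with no step beyond the scatter also possible. Compound 4 is expected to give about 25 nM in this assay, within 8 nM to 80 nM.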

Compound 4, inhibition constant: 6.3 nM
Estimate against measurement, compound 4: 4.0-fold (0.60 log units) above, outside the stated range (below it).
By their numbers in this assay, from the lowest: compounds 4 and 3 (each within the scatter of the next); then compound 2; then compound 1.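

On the carbonyl carbon, morpholin-4-yl in place of 2-aminoethyl gives a 1.8-fold lower number from compound 3 to compound 4 (0.25 log units; within the scatter) in this assay. This position therefore takes a six-membered non-aromatic ring without a hydrogen-bond donor as well as an open chain with one, and the donor of 2-aminoethyl is not required at this level of binding. Nothing at hand explains this result.

On these data alone, whether a carboxylic acid or a longer aminoalkyl chain on the same carbonyl carbon would stay at this level remains open. So does the contribution of the morpholine oxygen, which a piperidin-1-yl group would test.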